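Swapping the heteroaryl ring on a sulfonamide nitrogen

The source may report more compounds than this note shows. Statements on the series, on what has been measured and on what is new or still open speak of the compounds shown alone.

Three compounds share a core in which a chromone-type fragment is linked through an amino group to a benzenesulfonamide. Compound 1 `Cc1cc(C)nc(NS(=O)(=O)c2ccc(NCc3coc4ccccc4c3=O)cc2)n1` carries a 4,6-dimethylpyrimidin-2-yl group on the sulfonamide nitrogen; compound 2 `O=c1c(CNc2ccc(S(=O)(=O)Nc3nccs3)cc2)coc2ccccc12` carries a 1,3-thiazol-2-yl group there; compound 3 `O=C1/C(=C/c2coc3ccccc3c2=O)N=C(c2ccccc2)N1c1ccc(S(=O)(=O)Nc2nccs2)cc1` joins the two fragments through an imidazolone bridge. In a functional assay on A549 cells (Homo sapiens) for cytotoxicity, read by sulforhodamine B assay, with a stated time of 72 h (on this read-out lower numbers stand for stronger inhibition and higher numbers for weaker inhibition), compound 1 gives 55800 nM, compound 2 gives 25600 nM, and compound 3 gives 88400 nM. Within the data shown here, compound 2 thus shows the lowest number of the three, and both of its gaps lie beyond the scatter; the step of a 2.2-fold lower number from compound 1 to compound 2 (0.34 log units; beyond the scatter) is the only one that changes the group on the sulfonamide nitrogen alone.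

Compound 4 `Cc1cc(NS(=O)(=O)c2ccc(NCc3coc4ccccc4c3=O)cc2)no1` is not yet measured. Its change from compound 2 is 5-methyl-1,2-oxazol-3-yl in place of 1,3-thiazol-2-yl on a sulfonamide nitrogen. Among the measured compounds shown here, the one comparable step, from compound 1 to compound 2, was modest, so a modest step in this assay is expected for compound 4 as well, most likely a somewhat higher number, though a value within the scatter cannot be excluded. Compound 4 is therefore estimated at 40000 nM in this assay, between 15000 nM and 100000 nM, which would mean an expected step of a 1.6-fold higher number from compound 2 to compound 4 (0.19 log units; within the scatter).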

Compound 4, half-maximal inhibitory concentration: 59700 nM
Compound 4: middle estimate off by 1.5-fold (0.17 log units), on the low side, and the stated range covers the measured number.
By their numbers in this assay, from the lowest: compound 2; then compounds 1, 4 and 3 (each within the scatter of the next).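

In this assay, a third group on the sulfonamide nitrogen shows that the gain seen with 1,3-thiazol-2-yl does not carry over to every five-membered aromatic ring with two hetero atoms: placing 5-methyl-1,2-oxazol-3-yl there gives a 2.3-fold higher number from compound 2 to compound 4 (0.37 log units; beyond the scatter). Set against 4,6-dimethylpyrimidin-2-yl, the same group gives a 1.1-fold higher number from compound 1 to compound 4 (0.03 log units; within the scatter), so these two groups cannot be told apart here, and of the three groups at this position only 1,3-thiazol-2-yl stands apart from the others. Nothing measured on these compounds explains this difference.

The compounds shown leave open whether the 1,3-thiazol-2-yl result depends on that exact ring, as a 5-methyl-1,3-thiazol-2-yl or a 1,2-oxazol-3-yl group without its methyl would help to show. A pyridin-2-yl or plain phenyl ring on the same nitrogen would also test whether any hetero atom is needed there.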